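The source may report more compounds than this note shows. Statements on the series, on what has been measured and on what is new or still open speak of the compounds shown alone.

Measured so far in a functional assay on MCF7 cells (Homo sapiens) for antiproliferative activity; on this read-out higher numbers stand for weaker inhibition and lower numbers for stronger inhibition
- compound 1 `O=C(Nc1ccc(O)c2c(=O)cc(-c3ccccc3Cl)oc12)c1ccc(Cl)cc1` gives 4600 nM
- compound 2 `C[C@H](NC(=O)OC(C)(C)C)C(=O)Nc1ccc(O)c2c(=O)cc(-c3ccccc3Cl)oc12` gives 5500 nM

In this assay compound 2 stands at 5500 nM and is level with compound 1 within the scatter. The next compound is compound 3 `CCC(C)OC(=O)Nc1ccc(O)c2c(=O)cc(-c3ccccc3Cl)oc12` with this change from compound 2: sec-butoxy in place of 1-((tert-butoxycarbonyl)amino)ethyl on a carbonyl carbon. Here sec-butoxy takes the place of 1-((tert-butoxycarbonyl)amino)ethyl on a carbonyl carbon whose other neighbour is an amide-type nitrogen. Among the compounds with values here, one measured step bears on this, at the same carbonyl carbon: a 1.2-fold higher number from compound 1 to compound 2 (0.08 log units; within the scatter). Within the data shown here, that step stays within the scatter, but it is the only evidence, and no sec-butoxy compound has been measured. No shift beyond the scatter is therefore expected in this assay. The estimated change is a 1.1-fold lower number from compound 2 to compound 3 (0.04 log units; within the scatter) and also lies within the scatter. For compound 3 the expected value is 5000 nM with an estimated range of 2000 nM to 12500 nM.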

Compound 3, half-maximal inhibitory concentration: 30000 nM
Compound 3: middle estimate off by 6.0-fold (0.78 log units), on the low side, outside the stated range (above it).
By their numbers in this assay, from the lowest: compounds 1 and 2 (each within the scatter of the next); then compound 3.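

Sec-butoxy on the carbonyl carbon whose other neighbour is an amide-type nitrogen brings a 5.5-fold higher number from compound 2 to compound 3 (0.74 log units; beyond the scatter) and a 6.5-fold higher number from compound 1 to compound 3 (0.81 log units; beyond the scatter) in this assay and so gives the first shift beyond the scatter at this position. Within the data shown here, compounds 1 and 2 had stayed level despite carrying very different groups, so that level reading does not hold for every replacement here, and compound 3 is the one compound of the three joined to this carbonyl carbon through oxygen rather than carbon. Nothing at hand accounts for the weaker inhibition of compound 3.

Open, from the compounds shown here alone, is whether the shift follows the oxygen link or the sec-butyl chain itself, which a methoxy group, a longer alkoxy chain or a sec-butyl group joined through carbon could separate. Also open, going by these compounds, is whether a free amine in place of the protected amino group of compound 2 would stay level with compound 2.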